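Aminothiophene series: pyrazolyl in place of methylphenyl

The source may report more compounds than this note shows. Statements on the series, on what has been measured and on what is new or still open speak of the compounds shown alone.

Measured so far:
compound 1 `CC(C)(C)Cc1csc(N)c1C(=O)c1ccc(Cl)cc1` — 5%
compound 2 `Cc1ccc(-c2sc(N)c(C(=O)c3ccc(Cl)cc3)c2CC(C)(C)C)cc1` — 1%
compound 3 `Cc1cccc(-c2sc(N)c(C(=O)c3ccc(Cl)cc3)c2CC(C)(C)C)c1` — 1%

All three numbers come from an assay on CHO cells for displacement of a labelled ligand from adenosine receptor A3 (Homo sapiens), read by scintillation counting, tested at 10 uM; on this read-out higher numbers stand for more inhibition at the one concentration tested (going by the name of the read-out) and lower numbers for less inhibition. Compound 3 stands level with compound 2 at the digits shown, no change at the digits printed from compound 2 to compound 3 (within the scatter), and its nearest other neighbour is compound 1, a number 4 percentage points lower from compound 1 to compound 3 (within the scatter). None of the three compounds is separated from another beyond the scatter.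

Compound 4 `CC(C)(C)Cc1c(-c2cn[nH]c2)sc(N)c1C(=O)c1ccc(Cl)cc1` is not yet measured. Against compound 3 the change is 1H-pyrazol-4-yl in place of 3-methylphenyl on an aromatic carbon.

The measured steps that touch the same ring position are a number 4 percentage points lower from compound 1 to compound 2 (within the scatter) and a number 4 percentage points lower from compound 1 to compound 3 (within the scatter), each putting a methylphenyl in place of hydrogen, and no change at the digits printed from compound 2 to compound 3 (within the scatter), moving the methyl on that phenyl. Every one of them lies within the scatter. Within the data shown here, no measured step exchanges a carbon-only aromatic ring for a ring with two hetero atoms, so the step to compound 4 has no direct precedent. Given that every step so far has stayed within the scatter, compound 4 is expected to give 3% in this assay, a step of a number 2 percentage points higher from compound 3 to compound 4 (within the scatter) that is not expected to exceed the scatter, with an expected range of -8% to 14%.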

Compound 4, a percentage reported as inhibition, at one concentration (the size of the read-out at that concentration, not a potency): 1%
For compound 4 the middle estimate is 2 percentage points above the measured one; the measured number falls inside the stated range.
By their numbers in this assay, from the lowest: compounds 2, 3, 4 and 1 (each within the scatter of the next).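

In this assay, the position next to the ring sulfur shows no separation between a carbon-only aromatic ring and a five-membered aromatic ring with 2 hetero atoms: the exchange gives no change at the digits printed from compound 3 to compound 4 (within the scatter) and no change at the digits printed from compound 2 to compound 4 (within the scatter). Set against hydrogen at the same position, 1H-pyrazol-4-yl gives a number 4 percentage points lower from compound 1 to compound 4 (within the scatter), so the hydrogen-bond donor and acceptor entering with this smaller ring leave the number inside the scatter. No supporting measurement bears on why this position reads this way.

As far as these compounds go, with all four compounds within the scatter of one another, it stays open whether any group at this position can raise the inhibition seen in this assay. A carboxylic acid or an aminomethyl group there, or a longer chain in place of the neopentyl group, would be the next test of that.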